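Ethyl in place of hydrogen on compound 2

The source may report more compounds than this note shows. Statements on the series, on what has been measured and on what is new or still open speak of the compounds shown alone.

Measured in a functional assay on MCF7 cells (Homo sapiens) for inhibition, read by MTT assay, with a stated time of 3 days; on this read-out higher numbers stand for weaker inhibition and lower numbers for stronger inhibition:
- compound 1 `COc1cc(-c2nc3ccccc3s2)ccc1OCC(=O)NNC(=O)CN[C@@H](CS(=O)(=O)O)C(=O)O` gives 1870 nM
- compound 2 `COc1cc(-c2nc3ccccc3s2)ccc1OCC(=O)NNC(=O)CNC(=N)NCCC[C@H](N[N+](=O)[O-])C(=O)O` gives 1960 nM
- compound 3 `CCOC(=O)[C@@H](NCC(=O)NNC(=O)COc1ccc(-c2nc3ccccc3s2)cc1OC)[C@@H](C)CC` gives 1950 nM

The three values lie within the scatter of one another, so compound 2 holds no rank in this small set and sits level with compound 1 and compound 3.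

Next in line is compound 4 `CCOC(=O)[C@H](CCCNC(=N)NCC(=O)NNC(=O)COc1ccc(-c2nc3ccccc3s2)cc1OC)N[N+](=O)[O-]`, which has not yet been measured. Its change from compound 2 is ethyl in place of hydrogen on an oxygen next to a carbonyl group, which reads as carboxy to ethoxycarbonyl.

Within the data shown here, one measured step bears on this. It is a 1.0-fold higher number from compound 1 to compound 3 (0.02 log units; within the scatter), where 1-(ethoxycarbonyl)-2-methylbutyl replaces 1-carboxy-2-sulfoethyl on an amine nitrogen. That step also turns carboxy into ethoxycarbonyl, but it changes the rest of the group too, so it is only an indirect guide. Among the measured compounds shown here, no measured pair isolates the carboxy to ethoxycarbonyl change alone. Even so, the one relevant step stayed within the scatter, which gives no ground for expecting a shift in either direction in this assay.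

The expected result is a 1.0-fold lower number from compound 2 to compound 4 (0.00 log units; within the scatter), with no change beyond the scatter anticipated.

For compound 4 the estimate is 1950 nM, with an expected range from 1100 nM to 3400 nM.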

Compound 4, half-maximal inhibitory concentration: 1950 nM
The estimate for compound 4 equals the measured number at the digits printed; measured number inside the range.
By their numbers in this assay, from the lowest: compounds 1, 3, 4 and 2 (each within the scatter of the next).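

In this assay, among these compounds, the step of a 1.0-fold lower number from compound 2 to compound 4 (0.00 log units; within the scatter) is the first reading of ethyl in place of hydrogen on an oxygen next to a carbonyl group with nothing else in the structure differing. The earlier step of a 1.0-fold higher number from compound 1 to compound 3 (0.02 log units; within the scatter) also contained carboxy to ethoxycarbonyl but altered the rest of the group as well, whereas the new pair shows that carboxy(nitroamino)methyl and (ethoxycarbonyl)(nitroamino)methyl read level in this assay on their own. No measurement at hand bears on why the two read level.

Still open, as far as these compounds go, is whether a longer chain such as butyl, or a benzyl group, on the same oxygen would stay level with compound 2, and whether a primary amide in place of the carboxy would do the same. Since every compound shown sits within the scatter of the others, none of these structures yet marks a change at this position that moves the read-out, and the same ethyl on the carboxy of compound 1, with the sulfo group kept, also remains to be read.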